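This account rests on a few compounds, and the source may have more. Where it says the series, first, only, none or still open, it means among the compounds named here.

Measured compounds:
- compound 1, `CCC(=O)N1N=C(c2ccc(F)cc2)CC1c1cn(-c2ccccc2)nc1-c1ccc(Cl)c(Cl)c1`, 51.1%
- compound 2, `CC(=O)N1N=C(c2ccc(Cl)cc2)CC1c1cn(-c2ccccc2)nc1-c1ccc(Cl)c(Cl)c1`, 45.7%
- compound 3, `Clc1ccc(C2=NN(c3ccccc3)C(c3cn(-c4ccccc4)nc3-c3ccc(Cl)c(Cl)c3)C2)cc1`, 45.7%

In a functional assay on the whole organism (strain Wistar) for inhibition, with Rattus norvegicus as the target, read by paw edema, with a stated time of 30 min, at a dose of 50 mg/kg by the oral route (on this read-out lower numbers stand for less inhibition and higher numbers for more inhibition at the one dose given (going by the name of the read-out)), compound 3 stands level with compound 2, the two lowest numbers of the three; compound 1 gives a number only slightly higher, within the scatter. Compound 4, `CCC(=O)N1N=C(c2ccc(Cl)cc2)CC1c1cn(-c2ccccc2)nc1-c1ccc(Cl)c(Cl)c1`, has not yet been measured. It differs from compound 3 in one place: propanoyl in place of phenyl on an amine nitrogen in a ring. Among the compounds with values here, the one measured step that bears on this change is no change at the digits printed from compound 2 to compound 3 (within the scatter), where a phenyl replaced an acetyl at the same ring nitrogen without moving the read-out. Compound 1, which carries a propanoyl at that nitrogen, also sits within the scatter of compound 3. The step is therefore expected to be small, a number 2.3 percentage points higher from compound 3 to compound 4 (within the scatter), in no clear direction. Compound 4 is estimated at 48%, expected between 38% and 58%.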

Compound 4, a percentage reported as inhibition, in the whole organism at one dose (the size of the read-out at that dose, not a potency): 47.9%
Beside the measured number, compound 4's estimate is 0.1 percentage points above it; low and high end bracket the measured number.
By their numbers in this assay, from the lowest: compounds 2, 3, 4 and 1 (each within the scatter of the next).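

In this assay, the ring nitrogen carries a propanoyl or a phenyl with no step beyond the scatter, a number 2.2 percentage points higher from compound 3 to compound 4 (within the scatter), so a chain with a carbonyl and an aromatic ring are not told apart here. Methyl in place of hydrogen on the chain carbon bound to the carbonyl carbon also stays within the scatter, a number 2.2 percentage points higher from compound 2 to compound 4 (within the scatter), as does chloro in place of fluoro on the aromatic carbon, a number 3.2 percentage points lower from compound 1 to compound 4 (within the scatter). No measurement available explains why these numbers lie so close. As far as these compounds go, whether a longer chain, such as hexanoyl, or a carboxylic acid on this nitrogen would move the number beyond the scatter remains open.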